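Pyrazolyl chalcone series: adding a second methoxy group

This account rests on a few compounds, and the source may have more. Where it says the series, first, only, none or still open, it means among the compounds named here.

Working notes on a small set of pyrazole-linked chalcones tested in a functional assay on UACC-62 cells (Homo sapiens) for inhibition, read by sulforhodamine B assay, with a stated time of 48 h; on this read-out lower numbers stand for higher toxicity in this test and higher numbers for lower toxicity in this test. Compound 1, `COc1ccc(-c2cc(/C=C/C(=O)c3ccc(N)cc3)[nH]n2)cc1`, carries a single methoxy group on one aryl ring and an amino group on the other; in this assay compound 1 gives 5840 nM. Compound 2, `COc1cc(-c2cc(/C=C/C(=O)c3ccc(F)c(F)c3)[nH]n2)cc(OC)c1OC`, which pairs a trimethoxyphenyl ring with a difluorophenyl ketone, gives 35300 nM in this assay. Among the measured compounds shown here, of the two numbers, compound 1 holds the lower one, and the gap to compound 2 lies beyond the scatter of repeated measurements; no single-point step connects these two compounds, so their values are recorded side by side only.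

Compound 3, `COc1ccc(-c2cc(/C=C/C(=O)c3ccc(N)cc3)[nH]n2)cc1OC`, is the single-point relative of compound 1: methoxy in place of hydrogen on an aromatic carbon. For the measured compounds named here, no measured pair in this set isolates such a change, so there is no precedent to lean on. The working expectation is a step from compound 1 to compound 3 of a 1.1-fold higher number from compound 1 to compound 3 (0.05 log units; within the scatter), that is, no change beyond the scatter. Compound 3 is accordingly estimated at 6500 nM, with a range from 2000 nM to 22000 nM, pending the measurement.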

Compound 3, concentration lethal to 50% of the cells: 39600 nM
Beside the measured number, compound 3's estimate is 6.1-fold (0.78 log units) below it; measured number above the stated range.
By their numbers in this assay, from the lowest: compound 1; then compounds 2 and 3 (each within the scatter of the next).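

In this assay, the series gains its first single-point step, a 6.8-fold higher number from compound 1 to compound 3 (0.83 log units; beyond the scatter), so methoxy in place of hydrogen on this aromatic carbon, ortho to a methoxy group, shifts the read-out towards lower toxicity in this test by more than the scatter. The gap between compounds 1 and 2 could not be tied to any one site, since they differ in several places, whereas this pair ties a change beyond the scatter to a single added group, with the amino-bearing ketone side and the rest of the core of compound 1 unchanged. Nothing in hand bears on the reason for this step.

This single pair leaves open whether the position responds to methoxy specifically or to any substituent, as a hydroxy group, a chlorine atom or a longer ethoxy chain on the same carbon would show. It also leaves open whether the step carries over to a different ketone partner, such as the difluorophenyl ketone of compound 2, where the amino group is absent.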